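This account rests on a few compounds, and the source may have more. Where it says the series, first, only, none or still open, it means among the compounds named here.

Compound 1 `N[C@H]1CC[C@H](Nc2c(C(=O)NCc3ccco3)nc(Br)c3cccnc23)CC1`: > 10000 nM
Compound 2 `COc1cccc(CNC(=O)c2nc(Br)c3cccnc3c2N[C@H]2CC[C@H](N)CC2)c1`: 7000 nM
Compound 3 `COc1ccc(CNC(=O)c2nc(Br)c3cccnc3c2N[C@H]2CC[C@H](N)CC2)cc1`: 5000 nM

In a functional assay on MDA-MB-435 cells (Homo sapiens) for cytotoxicity, read by MTT assay, with a stated time of 72 h (a lower number here means a stronger inhibitor, a higher number a weaker inhibitor), compound 3 gives 5000 nM, within the scatter of compound 2 at 7000 nM. The entry for compound 1 is a limit of the assay and not a number: > 10000 nM. Compound 4 `N[C@H]1CC[C@H](Nc2c(C(=O)NCc3ccc(Cl)cc3Cl)nc(Br)c3cccnc23)CC1` differs from compound 3 in one place, on a saturated chain carbon bound to an amide-type nitrogen: 2,4-dichlorophenyl in place of 4-methoxyphenyl on a saturated chain carbon bound to an amide-type nitrogen.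

Among the measured compounds shown here, all the measured steps are changes at this same place. Two start from the limit of compound 1, and what they show is only a floor: an at least 1.4-fold lower number from compound 1 to compound 2 (0.15 log units; that floor lies within the scatter) and an at least 2.0-fold lower number from compound 1 to compound 3 (0.30 log units; that floor lies within the scatter). For the measured compounds named here, the only step with a true number on both sides is a 1.4-fold lower number from compound 2 to compound 3 (0.15 log units; within the scatter), so no change beyond the scatter is expected in this assay. No ring bearing chlorine has been measured yet, which leaves this expectation loose. The expected step is a 1.3-fold lower number from compound 3 to compound 4 (0.10 log units; within the scatter). Compound 4 is estimated at 4000 nM, with an expected range of 1200 nM to 10000 nM.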

Compound 4, half-maximal inhibitory concentration: 5800 nM
The estimate for compound 4 lay 1.5-fold (0.16 log units) below the measured number; measured number inside the range.
By their numbers in this assay, from the lowest: compounds 3, 4 and 2 (each within the scatter of the next). At a limit, above all of these: compound 1.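

The first ring bearing chlorine at this place, 2,4-dichlorophenyl, gives no difference beyond the scatter in this assay from either methoxy-bearing ring: a 1.2-fold higher number from compound 3 to compound 4 (0.06 log units; within the scatter), and a 1.2-fold lower number from compound 2 to compound 4 (0.08 log units; within the scatter). So exchanging 4-methoxyphenyl, which holds a hydrogen-bond acceptor, for 2,4-dichlorophenyl, which holds none, leaves these numbers indistinguishable. Compound 1 stands at a limit of the assay, so an at least 1.7-fold lower number from compound 1 to compound 4 (0.23 log units; that floor lies within the scatter) is only a floor, and furan-2-yl cannot be ranked against the 2,4-dichlorophenyl ring: the limit of > 10000 nM in this assay, at which 1 of the 4 values shown sits.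

As far as these compounds go, it remains open whether a carboxylic acid, an amine or a longer chain in place of these rings would give a step beyond the scatter. From the compounds shown here alone, it also remains open whether a ring with a single chlorine would read like the 2,4-dichlorophenyl ring.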